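Adding Benzyloxy to Compound 2: An Expected Drop

The compounds below may be only part of what the source reports. "The series", "measured", "known", "first", "only" and "open" are said of these compounds alone.

Compound 2 `Cc1ccc(S(=O)(=O)n2cc(-c3cc(C(F)(F)F)ccn3)c3ccccc32)cc1` gives the highest of the three numbers measured in a functional assay on P388 cells (Mus musculus) for inhibition, tested at 100 uM (on this read-out lower numbers stand for a weaker effect and higher numbers for a stronger effect at the one concentration tested), with 49.9%. Compound 1 `COc1ccc2c(c1)c(-c1cc(C(F)(F)F)ccn1)cn2S(=O)(=O)c1ccc(C)cc1` gives 15.6%, and compound 3 `Cc1ccc(S(=O)(=O)n2cc(-c3cc(C(F)(F)F)cc(-c4cn(S(=O)(=O)c5ccc(C)cc5)c5cc(Br)ccc45)n3)c3ccc(Br)cc32)cc1` gives 8.9%. For the measured compounds named here, the only single-site step among them, a number 34.3 percentage points higher from compound 1 to compound 2 (beyond the scatter), shows that taking away a methoxy group raised the read-out well beyond the scatter. Compound 4 `Cc1ccc(S(=O)(=O)n2cc(-c3cc(C(F)(F)F)ccn3)c3cc(OCc4ccccc4)ccc32)cc1` differs from compound 2 by benzyloxy in place of hydrogen on an aromatic carbon. This change runs in the opposite direction to that step, since an oxygen-bearing group again enters on an aromatic carbon. Going by the values given here, a downward step of comparable size is therefore expected, though benzyloxy is not methoxy and no measured step covers that difference. Compound 4 is expected to give 22%, within 5% to 48%. That estimate means a step of a number 27.9 percentage points lower from compound 2 to compound 4 (beyond the scatter).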

Compound 4, a percentage reported as inhibition, at one concentration (the size of the read-out at that concentration, not a potency): 2.2%
The estimate for compound 4 lay 19.8 percentage points above the measured number; the measured number lies below the stated range.
By their numbers in this assay, from the lowest: compounds 4, 3 and 1 (each within the scatter of the next, the first and the last beyond it); then compound 2.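

On this aromatic carbon, benzyloxy gives a number 47.7 percentage points lower from compound 2 to compound 4 (beyond the scatter) in this assay and so exceeds the fall seen with methoxy, which means that neither oxygen-linked group keeps the read-out of the unsubstituted compound. Extending the oxygen substituent also matters, since phenyl on the saturated chain carbon gives a number 13.4 percentage points lower from compound 1 to compound 4 (beyond the scatter) as a further fall. Nothing available explains these falls. As far as these compounds go, it remains open whether a hydroxyl group, an amine or a fluorine atom on this carbon would keep the read-out near that of compound 2.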